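A few compounds are considered here, and "the series" means these few. Any claim that something is new, unique, unknown or untested is made for them only; others in the source may bear on it.

Of the compounds shown here, three built on one shared core have been measured in an assay on CHO cells for displacement of a labelled ligand from adenosine receptor A1 (Homo sapiens), read by scintillation counting, with a stated time of 90 min, in the presence of a further agent that is not named here; on this read-out higher numbers stand for weaker inhibition and lower numbers for stronger inhibition. Compound 1 `CCCn1c(=O)[nH]c2nc(-c3ccc(S(=O)(=O)N4CCN(c5cccc(F)c5)CC4)cc3)[nH]c2c1=O` gives a value that is only a limit of the assay, > 1000 nM. Compound 2 `CCCn1c(=O)[nH]c2nc(-c3ccc(S(=O)(=O)N4CCN(c5ccccc5)CC4)cc3)[nH]c2c1=O` gives 364 nM. Compound 3 `CCCn1c(=O)[nH]c2nc(-c3ccc(S(=O)(=O)N4CCN(c5ccc(I)cc5)CC4)cc3)[nH]c2c1=O` likewise reaches only a limit of the assay, > 1000 nM. Compound 3 thus stands at the weak end of what has been seen, alongside compound 1, both resting on the limit described by the limit of > 1000 nM in this assay, at which 2 of the 3 values shown sit. Removing the fluoro gave an at least 2.7-fold lower number from compound 1 to compound 2 (0.43 log units; beyond the scatter), while adding the iodo gave an at least 2.7-fold higher number from compound 2 to compound 3 (0.43 log units; beyond the scatter); the comparison a step that the two limits leave unreadable from compound 1 to compound 3 cannot be read between two limits.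

Compound 4 `CCCn1c(=O)[nH]c2nc(-c3ccc(S(=O)(=O)N4CCN(Cc5ccc(Br)cc5)CC4)cc3)[nH]c2c1=O` differs from compound 3 by 4-bromobenzyl in place of 4-iodophenyl on an amine nitrogen in a ring. Within the data shown here, no measured step covers a benzyl group on the ring nitrogen; the halogen steps that exist show a fluoro or an iodo on the phenyl ring ending at or pushing toward the limit. Compound 3 itself sits at that limit, and an at least 2.7-fold higher number from compound 2 to compound 3 (0.43 log units; beyond the scatter) tells only how far down one must go merely to reach a number. Compound 4 is therefore expected in this assay at about 1500 nM, within 400 nM to 6000 nM. That estimate means an expected step that the limit leaves unreadable from compound 3 to compound 4, staying near the limit already seen.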

Compound 4, inhibition constant: > 1000 nM
Compound 4: only a limit was reported; the forecaster's own chance of this, stated with the estimate: 60%; the middle value lies beyond the limit too.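

In this assay compound 4 gives > 1000 nM, which is a limit of the assay and not a number, and it joins the other compounds that end there: the limit of > 1000 nM in this assay, at which 3 of the 4 values shown sit. Placing 4-bromobenzyl on the amine nitrogen in the ring, in place of the phenyl, gives an at least 2.7-fold higher number from compound 2 to compound 4 (0.43 log units; beyond the scatter), so the move away from the plain phenyl of compound 2 now goes the same way with a benzyl group as it did with the fluoro and iodo phenyl groups. The steps from compound 1 and from compound 3 to compound 4 have limits at both ends and cannot be read.

Compound 2 remains the only compound here with a true number, and nothing shown separates the part played by the benzyl group from that of the bromo, which a plain benzyl group on the same nitrogen could do. Also open, as far as these compounds go, are how far past the limit compound 1, compound 3 and compound 4 lie, and how a methoxy group or an amine on the phenyl ring would read.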